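Trifluoromethyl oxadiazole isomers: the step to compound 3

A few compounds are considered here, and "the series" means these few. Any claim that something is new, unique, unknown or untested is made for them only; others in the source may bear on it.

Among the measured compounds shown here, in a physicochemical assay for solubility, at pH 7.4 (on this read-out higher numbers stand for higher solubility and lower numbers for lower solubility), compound 2 (`N#Cc1cnccc1COc1cnc(N2CCN(c3nc(C(F)(F)F)no3)CC2)nc1`) holds the higher of the two numbers so far, at 4800000 nM, while compound 1 (`N#Cc1cnccc1COc1cnc(N2CCN(c3noc(C(F)(F)F)n3)CC2)nc1`) gives 3100 nM. Compound 3 (`N#Cc1cnccc1COc1cnc(N2CCN(c3nnc(C(F)(F)F)o3)CC2)nc1`) has the same atoms as compound 2, joined differently: 5-(trifluoromethyl)-1,3,4-oxadiazol-2-yl in place of 3-(trifluoromethyl)-1,2,4-oxadiazol-5-yl on an amine nitrogen in a ring. Here 5-(trifluoromethyl)-1,3,4-oxadiazol-2-yl takes the place of 3-(trifluoromethyl)-1,2,4-oxadiazol-5-yl on an amine nitrogen in a ring. For the measured compounds named here, one measured step bears on this, a 1500-fold higher number from compound 1 to compound 2 (3.19 log units; beyond the scatter), a large step that also exchanges one oxadiazole isomer for another at this place. That single step gives no direction for a third isomer. Going by the values given here, with compound 2 at 4800000 nM, the top of the series so far, a downward step is expected, clear but smaller than that one. The expected step is a 9.6-fold lower number from compound 2 to compound 3 (0.98 log units; beyond the scatter). For compound 3 the estimated value is 500000 nM, with an expected range of 30000 nM to 5000000 nM.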

Compound 3, solubility: 120000 nM
Compound 3: the middle estimate sits 4.2-fold (0.62 log units) above what was measured; the range from low to high includes it.
By their numbers in this assay, from the lowest: compound 1; then compound 3; then compound 2.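

Across the three trifluoromethyl oxadiazole isomers, this assay gives a 40-fold lower number from compound 2 to compound 3 (1.60 log units; beyond the scatter) and a 39-fold higher number from compound 1 to compound 3 (1.59 log units; beyond the scatter), so compound 3 takes the middle rank with both steps large. The entering and leaving groups have the same heavy atoms and the same counts of donors and acceptors, yet all three compounds are separated beyond the scatter, showing that the way the five-membered ring is joined on the amine nitrogen in a ring can by itself move this read-out substantially. Nothing available on these compounds accounts for this order.

Still open, as far as these compounds go, is whether the same order of isomers holds when methyl replaces trifluoromethyl on each oxadiazole. Also open, from the compounds shown here alone, is where a simple amide or a 1,2,4-triazole on the same ring nitrogen would fall relative to these three compounds.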